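The source may report more compounds than this note shows. Statements on the series, on what has been measured and on what is new or still open speak of the compounds shown alone.

Measured so far in a functional assay on MGC-803 cells (Homo sapiens) for antiproliferative activity, read by MTT assay, with a stated time of 72 h; a higher number here means a weaker inhibitor, a lower number a stronger inhibitor:
- compound 1 `O=C1OCC[C@@H]1NC(=S)SCCOc1ccc([N+](=O)[O-])cc1`: > 100000 nM, a limit of the assay
- compound 2 `O=C1OCC[C@@H]1NC(=S)SCCOc1ccccc1`: 53800 nM
- compound 3 `O=C1OCC[C@@H]1NC(=S)SCCOc1ccccc1[N+](=O)[O-]`: 47000 nM

In this assay compound 2 holds the highest of the two numbers; the nearest is compound 3, a 1.1-fold lower number from compound 2 to compound 3 (0.06 log units; within the scatter). The value of compound 1 is only a limit (the limit of > 100000 nM in this assay, at which 1 of the 3 values shown sits). Compound 4 `CC(=O)c1ccc(OCCSC(=S)N[C@H]2CCOC2=O)cc1` differs from compound 2 in one place: acetyl in place of hydrogen on an aromatic carbon. Among the measured compounds shown here, the steps that bear on a change on this ring, an at least 1.8-fold lower number from compound 1 to compound 2 (0.26 log units; that floor lies within the scatter) and a 1.1-fold lower number from compound 2 to compound 3 (0.06 log units; within the scatter), show no movement beyond the scatter, so no step beyond the scatter is expected in this assay here either, with the direction open. Compound 4 is estimated at 50000 nM, range 20000 nM to 150000 nM, meaning a 1.1-fold lower number from compound 2 to compound 4 (0.03 log units; within the scatter) is expected.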

Compound 4, half-maximal inhibitory concentration: > 64000 nM
Compound 4 was reported as a limit; the forecaster's own chance of this, stated with the estimate: 25%; at least 1.2-fold (0.10 log units) between middle value and limit.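

In this assay compound 4 is reported only as a limit: the limit of > 64000 nM in this assay, at which 1 of the 4 values shown sits. Acetyl in place of hydrogen, para to a large group, gives an at least 1.1-fold higher number from compound 2 to compound 4 (0.07 log units; that floor lies within the scatter), a floor that does not clear the scatter, so this change shows no gain over hydrogen. The step between compound 1 and compound 4 cannot be read, as both are limits.

On these data alone, how far compound 4 truly lies from compound 2 stays open. Also open, as far as these compounds go, is whether an amine or a carboxylic acid in this place would move the number beyond the scatter.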